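Methyl to chloro on the aromatic ring of compound 3

The source may report more compounds than this note shows. Statements on the series, on what has been measured and on what is new or still open speak of the compounds shown alone.

Measured so far in a functional assay on NCI-H460 cells (Homo sapiens) for antiproliferative activity, read by MTT assay, with a stated time of 48 h (on this read-out lower numbers stand for stronger inhibition and higher numbers for weaker inhibition), are three compounds:
compound 1 (`O=C1Nc2ccc(Nc3ccc(Cl)cc3)cc2/C1=C\C1CCCCC1`) gives 13200 nM
compound 2 (`Cc1ccc(Nc2ccc3c(c2)C(CCC(C)C)C(=O)N3)cc1`) gives 55300 nM
compound 3 (`Cc1ccc(Nc2ccc3c(c2)C(CC2CCCCC2)C(=O)N3)cc1`) gives only a limit (> 100000 nM)

Compound 3 has a limit and not a number in this assay (> 100000 nM). Its standing on the numbers shown is therefore simply the limit of > 100000 nM in this assay, at which 1 of the 3 values shown sits ( and no exact rank can be given ).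

Compound 4 (`O=C1Nc2ccc(Nc3ccc(Cl)cc3)cc2C1CC1CCCCC1`) is the next compound to be read. Compared with compound 3 it carries chloro in place of methyl on an aromatic carbon ( chloro in place of methyl on an aromatic carbon ), so that 4-methylphenyl becomes 4-chlorophenyl.

Within the data shown here, no measured step makes this exchange. Among the measured compounds shown here, the only step available is an at least 1.8-fold higher number from compound 2 to compound 3 (0.25 log units; that floor lies within the scatter) ( cyclohexyl in place of isobutyl ), which concerns a different place in the structure and so gives no size for this change.

The nearest guide is compound 1 (13200 nM), which carries the same (4-chlorophenyl)amino group but differs elsewhere. A lower number is therefore expected, with much uncertainty. The expected change is an at least 2.8-fold lower number from compound 3 to compound 4 (0.45 log units; beyond the scatter) ( an estimate only ). For compound 4 the estimated value is 35000 nM ( expected range 12000 nM to 100000 nM).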

Compound 4, half-maximal inhibitory concentration: > 100000 nM
Compound 4 was reported as a limit; the forecaster's own chance of this, stated with the estimate: 25%; middle value at least 2.8-fold (0.45 log units) away from the limit.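

In this assay compound 4 gives only a limit, > 100000 nM. Compound 3 also gives only a limit, so no step can be read from compound 3 to compound 4. The compounds shown leave open whether chloro in place of methyl on the aromatic ring changes the read-out at all on this shared core.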